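Adding a Methoxy Group to a Growth Inhibitor Core

The compounds below may be only part of what the source reports. "The series", "measured", "known", "first", "only" and "open" are said of these compounds alone.

Compound 1 `CCOC(=O)/C=C1/C(=O)Nc2ccccc21` gives 81.4% in a functional assay on SAOS-2 cells (Homo sapiens) for inhibition, read by CCK-8 assay, with a stated time of 72 h, tested at 20 uM; on this read-out lower numbers stand for less inhibition of growth and higher numbers for more inhibition of growth at the one concentration tested.
Compound 2 `CC(C)(C)OC(=O)/C=C1/C(=O)Nc2ccccc21` gives 83.3% in this assay.

Compound 2 holds the top of these two numbers, yet only by a number 1.9 percentage points higher from compound 1 to compound 2 (within the scatter), a difference within the scatter. Compound 3 `COc1ccc2c(c1)NC(=O)/C2=C/C(=O)OC(C)(C)C` differs from compound 2 by methoxy in place of hydrogen on an aromatic carbon. Among the compounds with values here, no measured step touches the aromatic ring; the single step known, on the ester, barely moved the read-out. The step from compound 2 to compound 3 is therefore expected to be a number 3.3 percentage points lower from compound 2 to compound 3 (within the scatter), nothing beyond the scatter. Compound 3 is estimated to give 80%, within a range from 65% to 92%.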

Compound 3, percent growth inhibition at one concentration: 83.2%
The estimate for compound 3 lay 3.2 percentage points below the measured number; the measured number falls inside the stated range.
By their numbers in this assay, from the lowest: compounds 1, 3 and 2 (each within the scatter of the next).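

The aromatic ring of the shared core now has a measured step of its own: methoxy in place of hydrogen on an aromatic carbon gives a number 0.1 percentage points lower from compound 2 to compound 3 (within the scatter) in this assay. At this position, then, the added methoxy leaves growth inhibition unchanged within the scatter at the one concentration tested. Nothing measured here offers a reason for this.

As far as these compounds go, whether an amine or a carboxylic acid on this same aromatic carbon would behave like methoxy remains open. So does whether methoxy would give a similar number on another carbon of that ring.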